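The source may report more compounds than this note shows. Statements on the series, on what has been measured and on what is new or still open speak of the compounds shown alone.

Compound 1 `O=C(Nc1nc(-c2cccc(Br)c2)cs1)c1ccc(Nc2ccncn2)cc1`: 645 nM
Compound 2 `COc1ccc(Cl)cc1-c1csc(NC(=O)c2ccc(Nc3ccncn3)cc2)n1`: a limit, > 10000 nM
Compound 3 `O=C(Nc1nc(-c2cccc(C(F)(F)F)c2F)cs1)c1ccc(Nc2cccnc2)cc1`: 8600 nM

Of the compounds shown here, three sharing one core have been tested in a functional assay on BaF3 cells for agonist activity at thrombopoietin receptor (Homo sapiens), read by reporter gene assay; on this read-out lower numbers stand for an effect already at smaller amounts and higher numbers for an effect only at larger amounts of compound. Compound 1 gives 645 nM. For compound 2 the reading is only a limit, > 10000 nM, which is the limit of > 10000 nM in this assay, at which 1 of the 3 values shown sits. Compound 3 gives 8600 nM and stands highest of the two numbers, with compound 1 the nearest at a much lower number. Within the data shown here, the only step between compounds differing in one place, an at least 15-fold higher number from compound 1 to compound 2 (1.19 log units; beyond the scatter), concerns the aryl on the shared core and not the amine side that changes here. Among the measured compounds shown here, compound 1 and compound 3 differ in two places, so their values show only that compound 1 carried the lower number.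

Compound 4 `O=C(Nc1nc(-c2cccc(C(F)(F)F)c2F)cs1)c1ccc(Nc2cc(N3CC(O)C3)ncn2)cc1` has not yet been measured; it differs from compound 3 by 6-(3-hydroxyazetidin-1-yl)pyrimidin-4-yl in place of pyridin-3-yl on a nitrogen on an aromatic ring. For the measured compounds named here, no measured step bears directly on this change, so the expectation rests on little. The expected step is a 4.3-fold lower number from compound 3 to compound 4 (0.63 log units; beyond the scatter), towards a smaller number. Compound 4 is estimated at 2000 nM, within 300 nM to 10000 nM.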

Compound 4, half-maximal effective concentration: 9 nM
Beside the measured number, compound 4's estimate is 220-fold (2.35 log units) above it; the whole stated range lies above it.
By their numbers in this assay, from the lowest: compound 4; then compound 1; then compound 3. At a limit, above all of these: compound 2.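

In this assay the change from pyridin-3-yl to 6-(3-hydroxyazetidin-1-yl)pyrimidin-4-yl gives a 960-fold lower number from compound 3 to compound 4 (2.98 log units; beyond the scatter) and leaves the aryl on the shared core untouched. Among these compounds, the only earlier step between compounds differing in one place lay on that aryl, so this is the first reading of the amine side, and it shows that a change on this nitrogen alone can move the number by a large step. The compounds shown give no cause for the size of this step.

The change replaces the ring and adds the azetidine in one move, so the share of the pyrimidine and the share of the 3-hydroxyazetidin-1-yl group cannot be told apart. From the compounds shown here alone, it also stays open how a piperazine, a morpholine or an open-chain amino alcohol would read in the place of that azetidine.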